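Replacing 3-nitrophenyl with pyridin-3-yl on the chain

The source may hold more compounds than are shown below. What is called first, only, known or untested is meant among the compounds shown, and "the series" means these compounds.

Measured in a functional assay on HL-60 cells (Homo sapiens) for cytotoxicity, read by WST assay, with a stated time of 48 h; on this read-out higher numbers stand for weaker inhibition and lower numbers for stronger inhibition:
- Compound 1 `Oc1ccccc1/C=C/C[C@H]1C[C@@H]([C@@H](O)c2ccccc2)CO[C@@H]1c1ccccc1`: 10800 nM
- Compound 2 `COc1ccc(/C=C/C[C@H]2C[C@@H]([C@@H](O)c3ccccc3)CO[C@@H]2c2ccccc2)cc1`: 9010 nM
- Compound 3 `O=[N+]([O-])c1cccc(/C=C/C[C@H]2C[C@@H]([C@@H](O)c3ccccc3)CO[C@@H]2c2ccccc2)c1`: 6350 nM

Compound 3, at 6350 nM, is not separated from the other two compounds by more than the usual scatter. Compound 4 `O[C@@H](c1ccccc1)[C@H]1CO[C@H](c2ccccc2)[C@@H](C/C=C/c2cccnc2)C1` has not yet been measured. It differs from compound 3 by one change (pyridin-3-yl in place of 3-nitrophenyl on a double-bonded chain carbon bound to a double-bonded chain carbon). Going by the values given here, three measured steps bear on this place: a 1.7-fold lower number from compound 1 to compound 3 (0.23 log units; within the scatter), a 1.4-fold lower number from compound 2 to compound 3 (0.15 log units; within the scatter) and a 1.2-fold lower number from compound 1 to compound 2 (0.08 log units; within the scatter). All three stay within the scatter, so the groups tried here have not moved the number in this assay in any clear way. Among the compounds with values here, no measured compound carries pyridin-3-yl, so the data offer no direct guide to that group. No shift beyond the scatter is therefore expected in either direction, and the estimated change is a 1.3-fold higher number from compound 3 to compound 4 (0.10 log units; within the scatter). For compound 4 the estimate is 8000 nM, expected to fall between 4000 nM and 16000 nM.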

Compound 4, half-maximal inhibitory concentration: > 100000 nM
Compound 4 was reported as a limit; the forecaster's own chance of this, stated with the estimate: 5%; middle value at least 12-fold (1.09 log units) from the limit.
By their numbers in this assay, from the lowest: compounds 3, 2 and 1 (each within the scatter of the next). At a limit, above all of these: compound 4.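

In this assay, going by these compounds alone, the earlier compounds suggested that the group on a double-bonded chain carbon bound to a double-bonded chain carbon could vary with no clear effect, but pyridin-3-yl breaks that picture, with an at least 15-fold higher number from compound 3 to compound 4 (1.19 log units; beyond the scatter), an at least 11-fold higher number from compound 2 to compound 4 (1.04 log units; beyond the scatter) and an at least 9.2-fold higher number from compound 1 to compound 4 (0.96 log units; beyond the scatter). The value of compound 4, > 100000 nM, is a limit of the assay and not a number. This position is therefore not indifferent to its group: the three substituted carbon-only rings stay within the scatter of one another, while the ring with a hetero atom stands clearly apart from two of them and at least modestly from the third.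

Compound 4 is the only compound with a ring nitrogen and also the only one with no substituent on that ring, and the compounds shown cannot separate these two features. Unsubstituted phenyl, or a pyridin-3-yl carrying a methoxy group, at this place would be needed to tell them apart.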